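Phenoxy to dimethylamino exchange: expected cytotoxicity shift

The source may report more compounds than this note shows. Statements on the series, on what has been measured and on what is new or still open speak of the compounds shown alone.

Compound 2 `Cc1cc(O)cc(-c2nn(CC#N)cc2-c2ccnc(-c3ccc(Oc4ccccc4)cc3)c2)c1` gives -81% in a functional assay on UO-31 cells (Homo sapiens) for cytotoxicity, read by sulforhodamine B assay, with a stated time of 48 h, tested at 10 uM (on this read-out lower numbers stand for a stronger effect and higher numbers for a weaker effect at the one concentration tested), the lowest of the two numbers in hand. Compound 1 `COc1cc(C)cc(-c2c(-c3ccnc(-c4ccc(N(C)C)cc4)c3)cnn2CC#N)c1` gives 7% in this assay, a number higher than compound 2 by more than the scatter, though the two differ in more than one place. Compound 3 `Cc1cc(O)cc(-c2nn(CC#N)cc2-c2ccnc(-c3ccc(N(C)C)cc3)c2)c1` carries the change (dimethylamino in place of phenoxy on an aromatic carbon). The step of a number 41 percentage points higher from compound 2 to compound 3 (beyond the scatter) is expected to be a rise beyond the scatter, toward a weaker effect, because compound 1 with the same dimethylamino gives 7%. Compound 3 is expected at -40%, within -85% to 10%.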

Compound 3, a percentage reported as activity, at one concentration (the size of the read-out at that concentration, not a potency): -19%
Compound 3: middle estimate off by 21 percentage points, on the low side; the measured number falls inside the stated range.
By their numbers in this assay, from the lowest: compound 2; then compound 3; then compound 1.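

With the rest of the molecule held constant, dimethylamino in place of phenoxy gives a number 62 percentage points higher from compound 2 to compound 3 (beyond the scatter) in this assay. This place, para to a large group, therefore matters to the read-out, although compound 3 still gives -19%. The two groups count the same hydrogen-bond donors and acceptors, so those counts do not separate compound 2 from compound 3. Nothing measured here accounts for the step. Open, going by these compounds, is whether the step follows the loss of the aromatic ring or the entry of the amine nitrogen; a morpholine or a benzyl group at this place would bear on that.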